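Swapping the Chain on a Carbonyl: Expected Antiproliferative Gain

A few compounds are considered here, and "the series" means these few. Any claim that something is new, unique, unknown or untested is made for them only; others in the source may bear on it.

Three amides have been measured in a functional assay on MCF7 cells (Homo sapiens) for antiproliferative activity, with a stated time of 48 h; a lower number here means a stronger inhibitor, a higher number a weaker inhibitor. Compound 1 `O=C(CCCCl)Nc1ccc(I)cc1` returns only a limit in this assay, > 100000 nM. Compound 3 `C=CC(=O)Nc1ccc(I)cc1` shares the core of compound 1 and differs from it in one place (vinyl in place of 3-chloropropyl on a carbonyl carbon); in this assay compound 3 gives 17000 nM. The measured step of an at least 5.8-fold lower number from compound 1 to compound 3 (0.76 log units; beyond the scatter) can only be given as a bound, since the value of compound 1 sits at the limit of > 100000 nM in this assay, at which 1 of the 3 values shown sits.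

Compound 2 `CC(C)(C)c1ccc(CNC(=O)CCCCl)cc1` has a core that differs from the core of compound 1 in a way that is not broken down here; in this assay compound 2 gives 92000 nM, the highest of the two numbers, with compound 3 the nearest at a gap beyond the scatter.

Compound 4 `C=CC(=O)NCc1ccc(C(C)(C)C)cc1` has not yet been measured. It stands to compound 2 exactly as compound 3 stands to compound 1: the same change, made at a place described in the same words for both pairs (vinyl in place of 3-chloropropyl on a carbonyl carbon). The expectation for compound 4 therefore rests on a single measured pair. Because the measured step of an at least 5.8-fold lower number from compound 1 to compound 3 (0.76 log units; beyond the scatter) lies beyond the scatter, the same change is expected to produce a step of about a 5.4-fold lower number from compound 2 to compound 4 (0.73 log units; beyond the scatter) this time as well. On that basis compound 4 is estimated at 17000 nM, most likely falling between 6000 nM and 50000 nM in this assay.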

Compound 4, half-maximal inhibitory concentration: > 100000 nM
Compound 4: a limit, no number (the forecaster's own chance of this, stated with the estimate: 5%); at least 5.8-fold (0.76 log units) between middle value and limit.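

In this assay compound 4 returns only a limit, > 100000 nM. Putting vinyl in place of 3-chloropropyl on a carbonyl carbon gives an at least 1.0-fold higher number from compound 2 to compound 4 (0.03 log units; that floor lies within the scatter), so the lower number seen on the core of compound 1 does not carry over to the core of compound 2, and the two steps differ clearly: the same change on two cores in this assay, an at least 5.8-fold lower number (0.76 log units; beyond the scatter) from compound 1 to compound 3 and an at least 1.0-fold higher number (0.03 log units; that floor lies within the scatter) from compound 2 to compound 4, at least 6.3-fold (0.80 log units) apart, beyond the scatter of two such steps Neither step has a known size, however, and with one pair on each core the series does not show which difference in the cores goes with the different outcome, nor how far apart the two steps truly lie, as some of the values rest on a limit: the limit of > 100000 nM in this assay, at which 2 of the 4 values shown sit.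

The compounds shown leave open whether the lower number of compound 3 goes with the vinyl group itself or with the loss of the 3-chloropropyl chain, a question that an ethyl group on the same carbonyl carbon could address on both cores. They also leave open how a longer chain or a chain ending in an amine would behave in this assay, and whether the change would carry over to any further core.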